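Does a chain double bond change compound 3's activity?

The source may report more compounds than this note shows. Statements on the series, on what has been measured and on what is new or still open speak of the compounds shown alone.

Measured so far in a functional assay on MCF7 cells (Homo sapiens) for antiproliferative activity, read by MTT assay; a lower number here means a stronger inhibitor, a higher number a weaker inhibitor 
- Compound 1 (`CCCC/C=C\CCCCCCCCCc1cc(=O)c2c(O)c(C)c(O)c(C)c2o1`) reports only a limit, > 67200 nM 
- Compound 2 (`CCCC/C=C\CCCCCCCCCc1cc(=O)c2c(O)cc(O)cc2o1`) gives 17500 nM 
- Compound 3 (`CCCCCCCCCCCCCCCc1cc(=O)c2c(O)c(C)c(O)cc2o1`) gives 43200 nM 

Of the two exact values, compound 3 at 43200 nM is the higher and so the weaker, and the gap to compound 2 at 17500 nM lies beyond the scatter. Compound 4 (`CCCC/C=C\CCCCCCCCCc1cc(=O)c2c(O)c(C)c(O)cc2o1`) has not been measured. It differs from compound 3 by hex-1-en-1-yl in place of hexyl on a saturated chain carbon, nine bonds along the chain from an aromatic carbon, with hex-1-en-1-yl in place of hexyl on a saturated chain carbon, nine bonds along the chain from an aromatic carbon. Compound 2 carries the same unsaturated chain and reads 17500 nM, but its core also differs, so it offers only a weak hint of a lower number. In this assay no change beyond the scatter is expected, and the estimated step is a 1.4-fold lower number from compound 3 to compound 4 (0.13 log units; within the scatter). Compound 4 is estimated at 32000 nM, with an expected range of 14000 nM to 65000 nM.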

Compound 4, half-maximal inhibitory concentration: 43200 nM
Estimate against measurement, compound 4: 1.4-fold (0.13 log units) below, and the stated range covers the measured number.
By their numbers in this assay, from the lowest: compound 2; then compounds 3 and 4 (each within the scatter of the next). At a limit, above all of these: compound 1.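

In this assay, the change at this chain position gives no change at the digits printed from compound 3 to compound 4 (within the scatter), so adding the double bond here does not alter the reading. With the unsaturated chain held constant, methyl in place of hydrogen on an aromatic carbon gives a 2.5-fold higher number from compound 2 to compound 4 (0.39 log units; beyond the scatter), which shows that the core matters more than this chain change. Compound 1 reports only a limit, so an at least 1.5-fold lower number from compound 1 to compound 4 (0.19 log units; that floor lies within the scatter) is a floor rather than a measured size: the limit of > 67200 nM in this assay, at which 1 of the 4 values shown sits.

Going by these compounds, whether a shorter chain or a chain carrying a carboxylic acid would move the number remains open. So does whether the double bond would also make no difference on the core of compound 2.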